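A few compounds are considered here, and "the series" means these few. Any claim that something is new, unique, unknown or untested is made for them only; others in the source may bear on it.

In a functional assay on HCT-116 cells (Homo sapiens) for antiproliferative activity, read by MTT assay, with a stated time of 48 h (a higher number here means a weaker inhibitor, a lower number a stronger inhibitor), compound 1 `COc1ccc(-c2c(Nc3ccc(F)cc3)c3ccccc3oc2=O)cc1` gives 39400 nM, and compound 3 `COc1ccc(-c2c(Nc3ccc(C)cc3)c3ccc(OC)cc3oc2=O)cc1` gives 82400 nM. For compound 2 `COc1ccc(-c2c(Nc3ccc(F)cc3)c3ccc(OC)cc3oc2=O)cc1` the result reads "not determined" (no result reported), so it has no single number in this assay and can only be placed loosely through these two relatives.

The compound still awaiting measurement is compound 4 `COc1ccc2c(Nc3ccc(F)cc3)c(C(=O)C(F)(F)F)c(=O)oc2c1`, which keeps the (4-fluorophenyl)amino group. The structural change is (trifluoromethyl)carbonyl in place of 4-methoxyphenyl on an aromatic carbon. Here (trifluoromethyl)carbonyl stands in place of 4-methoxyphenyl on an aromatic carbon, ortho to a (4-fluorophenyl)amino group, and the six-membered aromatic ring of carbon only leaves with the departing group.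

Among the measured compounds shown here, no measured pair shows this replacement, and compound 2 itself offers no starting value, so the size of the step in this assay cannot be read from the data. For the measured compounds named here, the only anchors are compound 1 at 39400 nM and compound 3 at 82400 nM. Against these, a moderate step towards a stronger inhibitor is expected, although an outcome within the usual scatter of these anchors would be quite possible. Compound 4 is estimated at 22000 nM, with an expected range of 6000 nM to 80000 nM.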

Compound 4, half-maximal inhibitory concentration: 11700 nM
Estimate against measurement, compound 4: 1.9-fold (0.27 log units) above, and the stated range covers the measured number.
By their numbers in this assay, from the lowest: compound 4; then compound 1; then compound 3.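

In this assay compound 4 gives 11700 nM but no step can be read from this result: compound 2, which differs from compound 4 in one place, has no number there. The compounds shown leave open what replacing 4-methoxyphenyl with (trifluoromethyl)carbonyl does on its own in this assay. Nothing shown bears on a cause for this value.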